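The source may hold more compounds than are shown below. What is called first, only, known or untested is meant among the compounds shown, and "the series" means these compounds.

Measured compounds:
Compound 1, `COC(=O)c1c(Nc2ccccc2)sc(C(=O)c2ccc(OC)cc2)c1C`, 18%
Compound 2, `COC(=O)c1c(Nc2ccccc2)sc(C(=O)c2ccc(C)cc2)c1C`, 3.16%
Compound 3, `COc1ccc(C(=O)c2sc(Nc3ccc(C)cc3)c(C(=O)O)c2C)cc1`, reported as "not active" (no number reported)

In a functional assay, with a stated time of 150 min, tested at 10 ug/mL (a lower number here means a weaker effect, a higher number a stronger effect of the compound at the concentration tested), compound 1 gives 18% and compound 2 gives 3.16%. The two differ by methoxy in place of methyl on an aromatic carbon, and this change gives a number 14.8 percentage points higher from compound 2 to compound 1 (beyond the scatter). Compound 3 carries the same methoxy on the benzoyl ring as compound 1, but its core is a different one; the difference between the two cores is not broken down here. In this assay compound 3 is reported as "not active" (no number reported), without a number.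

Compound 4, `COc1ccc(Nc2sc(C(=O)c3ccc(OC)cc3)c(C)c2C(=O)O)cc1`, has not yet been measured. It differs from compound 3 by methoxy in place of methyl on an aromatic carbon, the same change that was seen between compound 2 and compound 1. Since compound 3 gave no measurable effect and the earlier step of the same kind was only modest, compound 4 is expected to show at most a weak effect in this assay. Compound 4 is therefore estimated at 8%, with a range of 0% to 22% expected.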

Compound 4, a percentage reported as activity, at one concentration (the size of the read-out at that concentration, not a potency): 23.5%
Estimate against measurement, compound 4: 15.5 percentage points below; measured number outside the range, above it.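

In this assay, among these compounds, compound 4 gives 23.5% against a report of "not active" without a number for compound 3, and no step between the two can be read. The compounds shown leave open how large the change from (4-methylphenyl)amino to (4-methoxyphenyl)amino is on this core. No evidence at hand bears on this result.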